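Swapping a chlorophenyl amide for a chloropyridyl amide

The source may hold more compounds than are shown below. What is called first, only, known or untested is meant among the compounds shown, and "the series" means these compounds.

Of the compounds shown here, two sharing one core have been tested in a functional assay on HepG2 cells (Homo sapiens) for inhibition, read by MTT assay, with a stated time of 72 h; a higher number here means a weaker inhibitor, a lower number a stronger inhibitor. Compound 1 `Cc1noc(C)c1-c1cnc(N)c(Oc2ccc(C(=O)Nc3ccc(Cl)cc3)cc2)n1` gives 14400 nM. Within the data shown here, compound 2 `Cn1cc(-c2cnc(N)c(Oc3ccc(C(=O)Nc4ccc(Cl)cc4)cc3)n2)cn1` gives 11900 nM, and the two sit within the scatter of each other, the only measured step being a 1.2-fold lower number from compound 1 to compound 2 (0.08 log units; within the scatter). Compound 3 `Cn1cc(-c2cnc(N)c(Oc3ccc(C(=O)Nc4ncccc4Cl)cc3)n2)cn1` differs from compound 2 at another place: 3-chloropyridin-2-yl in place of 4-chlorophenyl on an amide-type nitrogen. The measured step concerns a different position, so nothing measured bears directly on this change. For compound 3, the expected step is therefore a 1.0-fold higher number from compound 2 to compound 3 (0.00 log units; within the scatter), nothing beyond the scatter. Compound 3 is estimated at 12000 nM, within 4000 nM to 36000 nM.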

Compound 3, half-maximal inhibitory concentration: 21700 nM
Estimate against measurement, compound 3: 1.8-fold (0.26 log units) below, within the range that was stated.
By their numbers in this assay, from the lowest: compounds 2, 1 and 3 (each within the scatter of the next).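

In this assay, among these compounds, the amide-type nitrogen now carries 3-chloropyridin-2-yl instead of 4-chlorophenyl, the first change at this position, and the result stays within the scatter (a 1.8-fold higher number from compound 2 to compound 3 (0.26 log units; within the scatter)). So this swap of ring and chlorine placement does not clearly alter the number. No evidence at hand accounts for the size of this step.

From the compounds shown here alone, whether an amine or a carboxylic acid on this ring would move the number beyond the scatter stays open. So does whether 3-chloropyridin-2-yl behaves alike when 3,5-dimethyl-1,2-oxazol-4-yl replaces 1-methyl-1H-pyrazol-4-yl.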